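Shortening the polyether chain: expected solubility of compound 4

This account rests on a few compounds, and the source may have more. Where it says the series, first, only, none or still open, it means among the compounds named here.

Three esters of the same phenol share a methoxy-terminated polyether chain of different length. Compound 1 `COCCOCCOCCOCCOCCOCCOCCOCCOCCOCCOC(=O)Oc1c(C(C)C)cccc1C(C)C` carries the longest chain, and in a physicochemical assay for solubility, in phosphate buffer, at pH 7.4 (a higher number here means a more soluble compound, a lower number a less soluble compound), compound 1 gives only a limit, > 314000 ug/mL. Compound 3 `COCCOCCOCCOCCOCCOCCOCCOC(=O)Oc1c(C(C)C)cccc1C(C)C` gives 2730 ug/mL in this assay, and compound 2 `COCCOCCOCCOCCOCCOCCOCC(=O)Oc1c(C(C)C)cccc1C(C)C` gives 2020 ug/mL, a number that sits within the scatter of compound 3 and is the lowest of the two numbers actually reported. Going by the values given here, the one step between measured compounds, an at least 110-fold lower number from compound 1 to compound 3 (2.06 log units; beyond the scatter), shows that a large loss of chain length costs a great deal of solubility, though part of that step is hidden behind the limit noted as the limit of > 314000 ug/mL in this assay, at which 1 of the 3 values shown sits.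

Compound 4 `COCCOCCOCCOCCOCC(=O)Oc1c(C(C)C)cccc1C(C)C` is the next shortening: hydrogen in place of (2-methoxyethoxy)methyl on a saturated chain carbon bound to an oxygen on a saturated carbon. Among the compounds with values here, the step is smaller than the one from compound 1 to compound 3, and the pair of compound 3 and compound 2 shows that a single unit removed does not move the number beyond the scatter. A modest decrease is therefore expected, a 1.7-fold lower number from compound 2 to compound 4 (0.23 log units; within the scatter). For compound 4 the estimate in this assay is 1200 ug/mL, in the range 400 ug/mL to 3000 ug/mL.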

Compound 4, solubility: 1580 ug/mL
The estimate for compound 4 lay 1.3-fold (0.12 log units) below the measured number, within the range that was stated.
By their numbers in this assay, from the lowest: compounds 4, 2 and 3 (each within the scatter of the next). At a limit, above all of these: compound 1.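

In this assay, removing (2-methoxyethoxy)methyl from the saturated chain carbon bound to an oxygen on a saturated carbon gave a 1.3-fold lower number from compound 2 to compound 4 (0.11 log units; within the scatter), so compound 2 and compound 4 cannot be told apart. Going by these compounds alone, this is the first measured shortening that stays within the scatter, and it contrasts with the earlier shortening, which gave an at least 110-fold lower number from compound 1 to compound 3 (2.06 log units; beyond the scatter). At these chain lengths, this change therefore leaves the number in this assay effectively in place, although this pair alone shows no trend.

As far as these compounds go, whether a much shorter chain ending in methoxymethyl, or a chain ending in an amine or a carboxylic acid, would behave the same remains open. Also open is where along the chains from compound 3 to compound 1 the large rise sets in, and compound 1 gives only a limit: the limit of > 314000 ug/mL in this assay, at which 1 of the 4 values shown sits.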